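Swapping the ring for a small amide in an oxazole ketone

The compounds below may be only part of what the source reports. "The series", "measured", "known", "first", "only" and "open" are said of these compounds alone.

Measured compounds: compound 1 `O=C(CCCCCCc1ccccc1)c1ncc(-c2ccc(F)cc2)o1`, 62 nM; compound 2 `Cc1cccnc1-c1cnc(C(=O)CCCCCCc2ccccc2)o1`, 15 nM; compound 3 `Cc1ccnc(-c2cnc(C(=O)CCCCCCc3ccccc3)o2)c1`, 0.6 nM.

In an assay (Rattus norvegicus) for inhibition of Fatty-acid amide hydrolase 1 (Homo sapiens) (on this read-out lower numbers stand for stronger inhibition and higher numbers for weaker inhibition), compound 3 gives the lowest number of the three, with a 25-fold lower number from compound 2 to compound 3 (1.40 log units; beyond the scatter) and a 100-fold lower number from compound 1 to compound 3 (2.01 log units; beyond the scatter), both beyond the scatter. Compound 4 `CNC(=O)c1cnc(C(=O)CCCCCCc2ccccc2)o1` differs from compound 3 in one place: methylcarbamoyl in place of 4-methylpyridin-2-yl on an aromatic carbon. For the measured compounds named here, none of the measured steps bears on this change directly; each of them exchanges one ring for another ring at the same position, whereas here the ring is removed altogether. Those ring-for-ring swaps already moved the read-out by large amounts, so losing the ring is expected to give a large upward step, a 330-fold higher number from compound 3 to compound 4 (2.52 log units; beyond the scatter), with wide uncertainty. Compound 4 is therefore estimated at 200 nM, within 30 nM to 1500 nM.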

Compound 4, inhibition constant: 7 nM
Compound 4: the middle estimate sits 29-fold (1.46 log units) above what was measured; the whole stated range lies above it.
By their numbers in this assay, from the lowest: compound 3; then compound 4; then compound 2; then compound 1.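

A ring is not required at this position: methylcarbamoyl, which has no ring, gives a lower number than the 3-methylpyridin-2-yl group (a 2.1-fold lower number from compound 2 to compound 4 (0.33 log units; beyond the scatter)) and the 4-fluorophenyl group (an 8.9-fold lower number from compound 1 to compound 4 (0.95 log units; beyond the scatter)). Only the 4-methylpyridin-2-yl group remains ahead of it in this assay (a 12-fold higher number from compound 3 to compound 4 (1.07 log units; beyond the scatter)). No measurement shown here explains why the small amide does so well.

Still open, on these data alone, is whether the amide hydrogen matters, and how a carboxylic acid, a dimethylamide or a longer amide chain would behave at this position.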